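A few compounds are considered here, and "the series" means these few. Any claim that something is new, unique, unknown or untested is made for them only; others in the source may bear on it.

Compound 1 `CCCn1c(=O)[nH]c2nc(-c3ccc(S(=O)(=O)N4CCN(Cc5cccc(C)c5)CC4)cc3)[nH]c2c1=O` and compound 2 `CCCn1c(=O)[nH]c2nc(-c3ccc(S(=O)(=O)N4CCN(c5cccc(Cl)c5)CC4)cc3)[nH]c2c1=O` share a core in which the ring nitrogen carries a hydrogen, and they differ only at the amine nitrogen of the piperazine ring. In an assay on CHO cells for displacement of a labelled ligand from adenosine receptor A2b (Homo sapiens), read by scintillation counting, with a stated time of 75 min, in the presence of a further agent that is not named here (a lower number here means a stronger inhibitor, a higher number a weaker inhibitor), compound 1 gives 0.397 nM, and compound 2 gives 0.342 nM; the change of 3-chlorophenyl in place of 3-methylbenzyl gives a 1.2-fold lower number from compound 1 to compound 2 (0.06 log units; within the scatter). Compound 3 `CCCn1c(=O)c2[nH]c(-c3ccc(S(=O)(=O)N4CCN(c5ccc(Cl)cc5)CC4)cc3)nc2n(CC)c1=O`, which carries an ethyl group on that ring nitrogen and a 4-chlorophenyl on the piperazine, gives 4.31 nM, the highest of the three numbers, beyond the scatter from both other compounds. Compound 4 `CCCn1c(=O)c2[nH]c(-c3ccc(S(=O)(=O)N4CCN(c5ccc(Cl)cc5)CC4)cc3)nc2n(C)c1=O` is compound 3 with hydrogen in place of methyl on a saturated chain carbon bound to an aromatic nitrogen. Read one bond further out, this is ethyl to methyl on that ring nitrogen. Among the measured compounds shown here, no measured pair isolates this change; compounds 1 and 2 show only that hydrogen at this nitrogen, together with a different piperazine substituent, goes with markedly lower numbers than compound 3. A methyl sits between ethyl and hydrogen, so a modest move toward those lower numbers is expected, of the size a 2.4-fold lower number from compound 3 to compound 4 (0.38 log units; beyond the scatter). Compound 4 is therefore estimated at 1.8 nM, within a range from 0.6 nM to 5.5 nM.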

Compound 4, inhibition constant: 1.91 nM
Beside the measured number, compound 4's estimate is 1.1-fold (0.03 log units) below it; the measured number falls inside the stated range.
By their numbers in this assay, from the lowest: compounds 2 and 1 (each within the scatter of the next); then compound 4; then compound 3.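

In this assay, ethyl to methyl on the aromatic nitrogen gives a 2.3-fold lower number from compound 3 to compound 4 (0.35 log units; beyond the scatter). Compound 3 and compound 4 differ in this one place, so this pair reads the change directly, which compounds 1 and 2 could not do, as each differs from compound 3 in more than one place. The step is modest but lies beyond the scatter, so with the rest of the structure held fixed, the number does respond to removing one carbon from this chain.

Still open, from the compounds shown here alone, is how a longer chain such as butyl, or a chain ending in an amine or a carboxylic acid, would read at this nitrogen, and where hydrogen there would fall with the 4-chlorophenyl kept on the piperazine. Nothing available here explains why the number moves with this change.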